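Aryl or cyclopropyl on the ring amide nitrogen

The source may hold more compounds than are shown below. What is called first, only, known or untested is meant among the compounds shown, and "the series" means these compounds.

Values in a functional assay on A549 cells (Homo sapiens) for antiproliferative activity, read by MTT assay, with a stated time of 72 h; on this read-out lower numbers stand for stronger inhibition and higher numbers for weaker inhibition:
- compound 1 `O=C1COc2ccc(-c3cccc(NS(=O)(=O)c4ccc(F)cc4)c3)cc2N1c1ccc(Cl)cc1`: 31600 nM
- compound 2 `O=C1COc2ccc(-c3cccc(NS(=O)(=O)c4ccc(F)cc4)c3)cc2N1C1CC1`: > 40000 nM (a limit)

Compound 2 is known only as a limit, > 40000 nM. Compound 3 `Cc1ccc(N2C(=O)COc3ccc(-c4cccc(NS(=O)(=O)c5ccc(F)cc5)c4)cc32)cc1` differs from it in one place: 4-methylphenyl in place of cyclopropyl on an amide-type nitrogen in a ring. Among the measured compounds shown here, one measured step bears on this change: an at least 1.2-fold higher number from compound 1 to compound 2 (0.10 log units; that floor lies within the scatter). The nearest comparison is therefore compound 1, which carries 4-chlorophenyl and gives 31600 nM. The expected step in this assay is an at least 1.3-fold lower number from compound 2 to compound 3 (0.12 log units; that floor lies within the scatter), small, towards a lower number, and possibly within the scatter. Compound 3 is expected at 30000 nM, with an estimated range of 14000 nM to 45000 nM.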

Compound 3, half-maximal inhibitory concentration: > 40000 nM
Compound 3 ended at the assay's limit; the forecaster's own chance of this, stated with the estimate: 40%; middle value at least 1.3-fold (0.12 log units) from the limit.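

In this assay, 4-methylphenyl on the amide-type nitrogen does not bring the series clear of the limit: compound 3 is known only as a limit, like compound 2, and the step between these two cannot be read. Methyl in place of chloro on the aromatic carbon gives an at least 1.2-fold higher number from compound 1 to compound 3 (0.10 log units; that floor lies within the scatter), so the two aryl compounds cannot be ordered. The read-out at this position therefore sits mostly at one limit: the limit of > 40000 nM in this assay, at which 2 of the 3 values shown sit.

Still open, going by these compounds, is whether a longer chain ending in an amine or a carboxylic acid on the amide-type nitrogen would give a number clear of that limit.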